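Ester swap on a triterpenoid: nitrophenyl to furanyl

The source may report more compounds than this note shows. Statements on the series, on what has been measured and on what is new or still open speak of the compounds shown alone.

Measured so far:
compound 1 `CC1=CC[C@H]2[C@@H]1CC=C(C)[C@@H](CC[C@H]1[C@]3(C)CC[C@H](OC(=O)c4ccc(Cl)cc4)C(C)(C)O[C@H]3CC[C@@]1(C)O)C2(C)C`: 12700 nM
compound 2 `CC1=CC[C@H]2[C@H](CC[C@]2(C)O)C(C)(C)[C@@H]1CC[C@H]1[C@]2(C)CC[C@H](OC(=O)c3ccc([N+](=O)[O-])cc3)C(C)(C)O[C@H]2CC[C@@]1(C)O`: 8900 nM

Both compounds were tested in a functional assay on MDA-MB-231 cells (Homo sapiens) for antiproliferative activity, read by MTT assay, with a stated time of 72 h; a higher number here means a weaker inhibitor, a lower number a stronger inhibitor. Compound 1 gives 12700 nM and compound 2 gives 8900 nM; the two numbers sit within the usual scatter of each other, so neither compound stands apart from the other, and both are weak inhibitors here.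

Compound 3 `CC1=CC[C@H]2[C@H](CC[C@]2(C)O)C(C)(C)[C@@H]1CC[C@H]1[C@]2(C)CC[C@H](OC(=O)c3ccco3)C(C)(C)O[C@H]2CC[C@@]1(C)O` is not yet measured. It differs from compound 2 in one place: furan-2-yl in place of 4-nitrophenyl on a carbonyl carbon. Among the compounds with values here, no step between measured compounds shows what such a change does, so the expectation rests only on the two numbers above. A step of modest size in either direction, or none beyond the scatter, is expected, and the expected step of a 1.1-fold higher number from compound 2 to compound 3 (0.05 log units; within the scatter) is therefore taken as small. Compound 3 is estimated to give 10000 nM, with a range from 4000 nM to 25000 nM.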

Compound 3, half-maximal inhibitory concentration: 14000 nM
Compound 3: middle estimate off by 1.4-fold (0.15 log units), on the low side; the range from low to high includes it.
By their numbers in this assay, from the lowest: compounds 2, 1 and 3 (each within the scatter of the next).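

In this assay, within the data shown here, putting furan-2-yl in place of 4-nitrophenyl on a carbonyl carbon gives a 1.6-fold higher number from compound 2 to compound 3 (0.20 log units; within the scatter), the first step at this place. A six-membered aromatic ring of carbon only and its nitro group give way to a smaller five-membered aromatic ring with one hetero atom, yet the two compounds cannot be told apart in this read-out, so this ester position tolerates the exchange without a readable difference. Nothing at hand bears on the reason for this result.

On these data alone, whether a straight carbon chain or a 4-aminophenyl group on the same carbonyl carbon would give a number clearly apart from these remains open. Also open, as far as these compounds go, is whether a free hydroxyl group in place of the whole ester would read any differently.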